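This account rests on a few compounds, and the source may have more. Where it says the series, first, only, none or still open, it means among the compounds named here.

- compound 1 `CC(C)CCCOc1cccc(O)c1C(=O)/C=C/c1ccc(O)cc1` gives 11400 nM
- compound 2 `CC(C)(C)CCOc1cccc(O)c1C(=O)/C=C/c1ccc(C(=O)O)cc1` gives 4770 nM
- compound 3 `CC(C)(C)CCOc1cccc(O)c1C(=O)/C=C/c1ccc(O)cc1` gives 3130 nM

In a functional assay on NCI-H23 cells (Homo sapiens) for antiproliferative activity, read by sulforhodamine B assay (on this read-out higher numbers stand for weaker inhibition of growth and lower numbers for stronger inhibition of growth), compound 1, at 11400 nM, has the highest of these three numbers, so it is the weakest inhibitor of the set. Compound 4 `O=C(/C=C/c1ccc(O)cc1)c1c(O)cccc1OCCC1CCCCC1` has not been measured yet. Its difference from compound 1 is this: cyclohexyl in place of isobutyl on a saturated chain carbon, two bonds along the chain from an oxygen on an aromatic ring.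

The most relevant measured change is a 3.6-fold lower number from compound 1 to compound 3 (0.56 log units; beyond the scatter), a modest step beyond the scatter, made by putting tert-butyl in place of isobutyl at that same place on the chain. The other step, a 1.5-fold lower number from compound 2 to compound 3 (0.18 log units; within the scatter), lies within the scatter and involves hydroxy and carboxy on an aromatic carbon, so it says little about this change. Cyclohexyl also replaces isobutyl, but no measured compound carries a ring at this place, so the precedent is only partial. A change in the same direction is therefore expected, probably smaller and quite uncertain. The expected step is a 2.3-fold lower number from compound 1 to compound 4 (0.36 log units; beyond the scatter). For compound 4 the estimated value is 5000 nM, with an expected range from 2000 nM to 12000 nM.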

Compound 4, concentration for 50% growth inhibition: > 30000 nM
Compound 4 ended at the assay's limit; the forecaster's own chance of this, stated with the estimate: 2%; middle value at least 6.0-fold (0.77 log units) from the limit.
By their numbers in this assay, from the lowest: compounds 3 and 2 (each within the scatter of the next); then compound 1. At a limit, above all of these: compound 4.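

In this assay, compound 4 gives no true number, only a limit of the assay: the limit of > 30000 nM in this assay, at which 1 of the 4 values shown sits.

Even so, cyclohexyl in place of isobutyl gives an at least 2.6-fold higher number from compound 1 to compound 4 (0.42 log units; beyond the scatter), a move in the opposite direction to the earlier 3.6-fold lower number from compound 1 to compound 3 (0.56 log units; beyond the scatter), and cyclohexyl in place of tert-butyl gives an at least 9.5-fold higher number from compound 3 to compound 4 (0.98 log units; beyond the scatter). This place on the chain therefore responds strongly to the shape of the group it carries, and a swap among groups made only of carbon can push the number either way.

From the compounds shown here alone, how far compound 4 lies past its limit remains unknown. Going by these compounds, it is also open whether a cyclopentyl ring, a longer straight chain or an amine at this place would fall nearer to compound 3 or to compound 4.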